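Benzylsulfanyl series: sulfonylguanidine analogues, cytotoxicity notes

The compounds below may be only part of what the source reports. "The series", "measured", "known", "first", "only" and "open" are said of these compounds alone.

Measured so far:
compound 1 `Cc1cc(S(=O)(=O)/N=C(\N)n2nccc2-c2ccccc2)c(SCc2cccc3ccccc23)cc1Cl` gives 58000 nM in a functional assay on MCF7 cells (Homo sapiens) for cytotoxicity, read by MTT assay, with a stated time of 72 h; on this read-out higher numbers stand for weaker inhibition and lower numbers for stronger inhibition;
compound 2 `Cc1ccc(CSc2cc(Cl)c(C)cc2S(=O)(=O)/N=C(\N)n2nccc2-c2ccccc2)cc1` gives 21000 nM in this assay.

Within the data shown here, compound 2 holds the lower of the two numbers so far; the nearest point is compound 1, and the step of a 2.8-fold lower number from compound 1 to compound 2 (0.44 log units; beyond the scatter) separates them. Compound 3 `Cc1cc(S(=O)(=O)/N=C(\N)n2nccc2-c2ccccc2)c(SCc2ccccc2Cl)cc1Cl` differs from compound 2 only at the group on the saturated chain carbon bound to a sulfur: 2-chlorophenyl in place of 4-methylphenyl on a saturated chain carbon bound to a sulfur. Among the measured compounds shown here, only one measured step bears on this position, the one from compound 1 to compound 2, which exchanged a naphthalen-1-yl for a 4-methylphenyl and was modest in size. For the measured compounds named here, no measured pair shows a 2-chlorophenyl at this place, so there is no direct precedent for the swap. A change no larger than the scatter is expected, in either direction. Compound 3 is estimated at 20000 nM (range 8000 nM to 50000 nM), which means an expected step of a 1.1-fold lower number from compound 2 to compound 3 (0.02 log units; within the scatter).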

Compound 3, half-maximal inhibitory concentration: 24000 nM
Compound 3: the middle estimate sits 1.2-fold (0.08 log units) below what was measured, and the stated range covers the measured number.
By their numbers in this assay, from the lowest: compounds 2 and 3 (each within the scatter of the next); then compound 1.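

In this assay, 2-chlorophenyl in place of 4-methylphenyl on a saturated chain carbon bound to a sulfur gives a 1.1-fold higher number from compound 2 to compound 3 (0.06 log units; within the scatter) and so does not separate these two substituted phenyl groups at this position. The replacement of naphthalen-1-yl by 2-chlorophenyl gives a 2.4-fold lower number from compound 1 to compound 3 (0.38 log units; beyond the scatter) in the same direction as a 2.8-fold lower number from compound 1 to compound 2 (0.44 log units; beyond the scatter) so that, among these three compounds, both phenyl compounds give lower numbers than the naphthalen-1-yl compound, with no exception. No supporting data are available to account for these differences.

As far as these compounds go, it remains open whether an unsubstituted phenyl, a pyridine ring, an amine or a carboxylic acid at this place would move the number in either direction. A longer chain between the sulfur and the ring is equally unresolved, as is whether the order of these compounds holds in other cell lines.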